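Removing the acetyl cap: from compound 3 toward compound 4

The source may hold more compounds than are shown below. What is called first, only, known or untested is meant among the compounds shown, and "the series" means these compounds.

This short series is built around a sulfone bridge linking two aromatic rings through a double bond, and it is judged by a functional assay on MDA-MB-468 cells (Homo sapiens) for cytotoxicity, read by MTT assay, with a stated time of 72 h; on this read-out higher numbers stand for weaker inhibition of growth and lower numbers for stronger inhibition of growth. Compound 1, with structure `COc1cc(OC)c(/C=C/S(=O)(=O)Cc2ccc(OC)c([N+](=O)[O-])c2)c(OC)c1`, carries a nitro group and gives "not determined" (no result reported). Compound 2, with structure `COc1ccc(CS(=O)(=O)/C=C/c2c(OC)cccc2OC)cc1N`, carries a free amino group and gives 60 nM, the only numerical result in the set. Compound 3, with structure `COc1cc(OC)c(/C=C/S(=O)(=O)Cc2ccc(OC)c(NC(C)=O)c2)c(OC)c1`, carries an acetamido group and gives "not determined" (no result reported), so compound 3 stands without a single number, as does compound 1.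

The step of interest leads to compound 4, with structure `COc1cc(OC)c(/C=C/S(=O)(=O)Cc2ccc(OC)c(N)c2)c(OC)c1`. The change is hydrogen in place of acetyl on a nitrogen on an aromatic ring; cut one bond further out it reads acetamido to amino. Among the measured compounds shown here, no pair of measured compounds gives a comparison for this step, so its size cannot be taken from the data. In this assay, for the measured compounds named here, the only anchor is compound 2, which shares the amino group and gives 60 nM; the direction of any step cannot be stated from the data. Compound 4 is therefore expected to land near that anchor, at an estimated 50 nM, within 15 nM to 200 nM.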

Compound 4, concentration for 50% growth inhibition: 30 nM
The estimate for compound 4 lay 1.7-fold (0.22 log units) above the measured number; measured number inside the range.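

In this assay, compound 4 gives the second numerical result in the set, and it shows that the free amino group keeps its place among the low numbers when the shared core carries one more methoxy. The step of a 2.0-fold lower number from compound 2 to compound 4 (0.30 log units; within the scatter) is methoxy in place of hydrogen on an aromatic carbon, so this change does not move the read-out beyond the usual scatter of repeated measurements, and no gain or loss can be claimed for it. The step from acetamido to amino cannot be read, nor can any step involving the nitro group, since neither compound 1 nor compound 3 has a number, and no supporting data bear on why these compounds behave as they do.

The compounds shown leave open whether the amino group itself matters, since nothing here compares it with another group on a number, and a hydroxyl or a methylamino group in its place would test that directly. They also leave open how much room there is on that aromatic carbon, where a longer chain such as ethoxy would show whether more than methoxy is accepted.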